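Swapping the Urea Tail: What to Expect for Compound 3

The source may report more compounds than this note shows. Statements on the series, on what has been measured and on what is new or still open speak of the compounds shown alone.

Of the compounds shown here, two have been measured in a functional assay on RPMI-8226 cells (Homo sapiens) for inhibition, read by sulforhodamine B assay, with a stated time of 48 h, tested at 0.1 uM; on this read-out higher numbers stand for a weaker effect at the one concentration tested and lower numbers for a stronger effect. Compound 1, `COc1cc(Cl)cc(-c2nn(-c3cccc(NC(=O)Nc4cc(C(F)(F)F)cc(C(F)(F)F)c4)c3)cc2-c2ccncc2)c1`, gives 87% in this assay. Compound 2, `COc1cc(Cl)cc(-c2nn(-c3cccc(NC(=O)Nc4ccc(Cl)c(Cl)c4)c3)cc2-c2ccncc2)c1`, gives 100% in this assay, the higher of the two numbers, with the number of compound 1 lying lower by more than the usual scatter.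

Compound 3, `COc1cc(Cl)cc(-c2nn(-c3cccc(NC(=O)Nc4cccc(C(F)(F)F)c4)c3)cc2-c2ccncc2)c1`, has not yet been measured. It differs from compound 2 in one place: 3-(trifluoromethyl)phenyl in place of 3,4-dichlorophenyl on an amide-type nitrogen. For the measured compounds named here, no measured pair shows this exact change, so its effect cannot be read from a measured step. Because compound 2 already stands at 100%, there is little room for compound 3 to move upward, and the expected step of a number 7 percentage points lower from compound 2 to compound 3 (within the scatter) is a small move downward, within the scatter or just beyond it. Compound 3 is estimated at 93% in this assay, with a likely range from 82% to 102%.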

Compound 3, a percentage reported as activity, at one concentration (the size of the read-out at that concentration, not a potency): 98%
For compound 3 the middle estimate is 5 percentage points below the measured one; measured number inside the range.
By their numbers in this assay, from the lowest: compound 1; then compounds 3 and 2 (each within the scatter of the next).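

On the urea tail, 3-(trifluoromethyl)phenyl in place of 3,4-dichlorophenyl on the amide-type nitrogen gives a number 2 percentage points lower from compound 2 to compound 3 (within the scatter) in this assay, so this swap produces no readable change. Putting hydrogen in place of one trifluoromethyl on an aromatic carbon of the tail gives a number 11 percentage points higher from compound 1 to compound 3 (beyond the scatter), the only single change shown here that goes beyond the scatter, and it is modest in size. Nothing measured here explains either step.

The compounds shown leave open how the read-out would move with a different kind of group on the tail ring, such as an amine or a carboxylic acid in place of trifluoromethyl. All of these numbers also come from a single concentration, so they do not show how potency would compare across a range of concentrations.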